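The compounds below may be only part of what the source reports. "The series", "measured", "known", "first", "only" and "open" are said of these compounds alone.

Measured compounds in this series:
Compound 1 `O=C1OC(Cc2nc(-c3ccc(-c4ccccc4)cc3)no2)c2ccccc21` gives > 40000 nM in this assay.
Compound 2 `CCC(C)Oc1ccc(C(O)C2OC(=O)c3c(OC)cc(OC)cc32)cc1` gives > 40000 nM in this assay.

In an ADME assay on RAW264.7 cells (Mus musculus) for cytotoxicity, read by MTT assay, with a stated time of 24 h, in the presence of a further agent that is not named here (a higher number here means a weaker inhibitor, a lower number a stronger inhibitor), compound 1 gives > 40000 nM, which is a limit of the assay and not a number. In this assay compound 2 likewise gives > 40000 nM, again a limit rather than a number. Compound 2 thus stands at the limit of > 40000 nM in this assay, at which 2 of the 2 values shown sit. Among the measured compounds shown here, with neither measured compound giving a number, no step between measured compounds can be read, and no size of effect is available from the data so far.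

Compound 3 `COc1cc(OC)c2c(c1)C(C(O)c1ccc(OCc3ccc(C#N)cc3)cc1)OC2=O` differs from compound 2 in one place: 4-cyanobenzyl in place of sec-butyl on an oxygen on an aromatic ring. Since both measured values sit at the limit, no shift beyond the usual scatter of this assay is expected from this change. The expected step in this assay is a step that the limit leaves unreadable from compound 2 to compound 3. Compound 3 is expected to give 60000 nM in this assay, with a range of 20000 nM to 200000 nM, and most likely to be reported only as a limit once more.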

Compound 3, half-maximal inhibitory concentration: > 40000 nM
Compound 3 ended at the assay's limit (the forecaster's own chance of this, stated with the estimate: 80%); the middle value is on the limit's open side.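

Compound 3, like compound 2, ends at a limit rather than a number, so no step can be read for 4-cyanobenzyl in place of sec-butyl. The compounds shown leave open whether any change to the shared core gives a number in this assay rather than a limit.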